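This account rests on a few compounds, and the source may have more. Where it says the series, first, only, none or still open, it means among the compounds named here.

Compound 1 `O=C(Nc1ccc(OC(F)(F)F)cc1)N1CCOC2(CCN(C(=O)c3cc(Cl)ccn3)CC2)C1`: 90 ug/mL. Compound 2 `N#Cc1ccc(C(=O)N2CCC3(CC2)CN(C(=O)Nc2ccc(C(F)(F)F)cc2)CCO3)cc1`: 85 ug/mL.

In an ADME assay on stomach for solubility, in simulated gastric fluid (on this read-out lower numbers stand for lower solubility and higher numbers for higher solubility), compound 2 gives 85 ug/mL, the lower of the two numbers shown, while compound 1 gives 90 ug/mL, which lies within the scatter of that value, so the two cannot be ordered. Compound 3 `O=C(Nc1ccc(C(F)(F)F)cc1)N1CCOC2(CCN(C(=O)c3ccccc3Cl)CC2)C1` has not yet been measured. Its difference from compound 2 is 2-chlorophenyl in place of 4-cyanophenyl on a carbonyl carbon. For the measured compounds named here, no measured pair shows this change, so the step can only be judged from the structures. For compound 3 the step of a 1.4-fold lower number from compound 2 to compound 3 (0.15 log units; within the scatter) is expected to be small and downward, within the scatter. Compound 3 is estimated at 60 ug/mL, with a range from 20 ug/mL to 150 ug/mL.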

Compound 3, solubility: 10 ug/mL
Compound 3: middle estimate off by 6.0-fold (0.78 log units), on the high side, outside the stated range (below it).
By their numbers in this assay, from the lowest: compound 3; then compounds 2 and 1 (each within the scatter of the next).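

In this assay, the group on the carbonyl carbon is not a neutral choice: 2-chlorophenyl in place of 4-cyanophenyl gives an 8.5-fold lower number from compound 2 to compound 3 (0.93 log units; beyond the scatter). For the compounds shown here, no earlier pair had tested a change in one place, and this is the only step so far that lies beyond the scatter.

Still open, from the compounds shown here alone, is whether the loss of the nitrile or the arrival of the chlorine carries this step, which a plain phenyl on the same carbonyl carbon could separate. Going by these compounds, the reading for an amine or a carboxylic acid at this place is also open. No measured evidence accounts for the step.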